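Working notes on the halogenated aryl series

The source may report more compounds than this note shows. Statements on the series, on what has been measured and on what is new or still open speak of the compounds shown alone.

Among the compounds with values here, compound 2 `C=CCn1c(=O)/c(=C\c2cccc(Br)c2)[nH]c(=O)/c1=C\c1ccccc1OC` gives 2300 nM in a functional assay on Huh-7 cells (Homo sapiens) for cytotoxicity, read by CCK-8 assay, with a stated time of 72 h (on this read-out higher numbers stand for weaker inhibition and lower numbers for stronger inhibition), and is the only member of the series with a reported number. Compound 1 `C=CCn1c(=O)/c(=C\c2ccc(Cl)c(Cl)c2)[nH]c(=O)/c1=C\c1ccccc1OC` is recorded in this assay as "not active" (no number reported). Compound 3 `C=CCn1c(=O)/c(=C\c2ccccc2F)[nH]c(=O)/c1=C\c1ccccc1OC` is not yet measured; it differs from compound 2 by 2-fluorophenyl in place of 3-bromophenyl on a double-bonded chain carbon bound to an aromatic carbon. Within the data shown here, no step between measured compounds exists, so the change cannot be read from the data; a modest loss in this assay is expected, given that compound 1, with another halogen pattern, is "not active" (no number reported). Compound 3 is expected to give 4500 nM, within 1500 nM to 15000 nM. The expected step is a 2.0-fold higher number from compound 2 to compound 3 (0.29 log units; within the scatter).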

Compound 3, half-maximal inhibitory concentration: 31300 nM
Compound 3: middle estimate off by 7.0-fold (0.84 log units), on the low side; measured number outside the range, above it.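

In this assay the exchange of 3-bromophenyl for 2-fluorophenyl on a double-bonded chain carbon bound to an aromatic carbon gives a 14-fold higher number from compound 2 to compound 3 (1.13 log units; beyond the scatter) and so shows that this read-out responds strongly to the change of aryl group. Both groups have the same counts of heavy atoms, donors and acceptors, so those counts do not separate them. Nothing available bears on the cause of the step.

The compounds shown leave open whether the identity of the halogen or its place on the ring carries the step, as neither 3-fluorophenyl nor 2-bromophenyl stands among them. From the compounds shown here alone, how a phenyl group bearing an amine would read at this position also remains open.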